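Furanylmethylamino in Place of Dimethylamino on an Inactive Parent

This account rests on a few compounds, and the source may have more. Where it says the series, first, only, none or still open, it means among the compounds named here.

Measured compounds:
compound 1 `CCCc1nn(C)c2c(NC(C)C)nc(/C=C/c3cccnc3)nc12`: 574000 nM
compound 2 `COc1ccc(Nc2nc(/C=C/c3ccccc3)nc3ccsc23)cc1`: > 1000000 nM
compound 3 `COc1cc(/C=C/c2nc(N(C)C)c3sccc3n2)cc(OC)c1OC`: > 1000000 nM

Of the compounds shown here, three have been measured in a functional assay on L02 cells (Homo sapiens) for inhibition, read by Griess assay, with stated times of 1 h and 24 h; a higher number here means a weaker inhibitor, a lower number a stronger inhibitor. For the measured compounds named here, compound 1 is the only one with a number, giving 574000 nM. For compound 2 the result is a limit of the assay, > 1000000 nM. Compound 3 likewise reaches only a limit, > 1000000 nM. Compound 3 therefore stands at the limit of > 1000000 nM in this assay, at which 2 of the 3 values shown sit, with no number of its own to compare against compound 1.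

Compound 4 `COc1cc(/C=C/c2nc(NCc3ccco3)c3sccc3n2)cc(OC)c1OC` has not yet been measured. It differs from compound 3 in one place: ((furan-2-yl)methyl)amino in place of dimethylamino on an aromatic carbon. Going by the values given here, no pair of measured compounds differs in a single place, so no measured step guides the prediction, and the three results span secondary and tertiary amines without a pattern.

The step of an at least 1.2-fold lower number from compound 3 to compound 4 (0.09 log units; that floor lies within the scatter) is expected to be small, with no direction beyond the scatter. Compound 4 is estimated at 800000 nM, within a range from 300000 nM to 3000000 nM, and a limit rather than a number remains likely.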

Compound 4, half-maximal inhibitory concentration: 189000 nM
Compound 4: middle estimate off by 4.2-fold (0.63 log units), on the high side; measured number below the stated range.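

For the compounds shown here, at this place, on an aromatic carbon next to the ring nitrogen, the earlier compounds offered no measured step, and the change now gives one: in this assay, ((furan-2-yl)methyl)amino in place of dimethylamino brings an at least 5.2-fold lower number from compound 3 to compound 4 (0.72 log units; beyond the scatter). The substituent on this carbon can therefore move the read-out on this parent, and compound 4 has a number where its parent has none. The step gives only a floor, and its full size cannot be read, since the parent's reading is a limit: the limit of > 1000000 nM in this assay, at which 2 of the 4 values shown sit.

The compounds shown leave open whether the furan ring, the amine hydrogen or the larger size of the new group goes with the lower number. A methylamino group or a benzylamino group on this carbon would begin to separate these features.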